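The source may hold more compounds than are shown below. What is called first, only, known or untested is meant among the compounds shown, and "the series" means these compounds.

Working notes on the series. Compound 2 `COc1ccc(Cn2c(CCc3c[nH]c4ccccc34)nnc2[C@H](NC(=O)c2ccccn2)c2c[nH]c3ccccc23)c(OC)c1` carries a (pyridin-2-yl)carbonyl amide and two methoxy groups on the benzyl arm; in a functional assay on CHO cells for antagonist activity at growth hormone secretagogue receptor type 1 (Homo sapiens) (a higher number here means a weaker inhibitor, a lower number a stronger inhibitor), compound 2 gives 19 nM, which is the second highest of the three numbers in hand. Its nearest neighbour is compound 1 `COc1ccc(Cn2c(CCc3c[nH]c4ccccc34)nnc2[C@H](NC(=O)C(C)(C)N)c2c[nH]c3ccccc23)c(OC)c1`, which in this assay gives 14 nM; the step of a 1.4-fold higher number from compound 1 to compound 2 (0.13 log units; within the scatter) is within the scatter. Its furthest neighbour is compound 3 `COc1ccc(Cn2c(CCc3c[nH]c4ccccc34)nnc2[C@H](NC(=O)c2ccccn2)c2c[nH]c3ccccc23)cc1`, which gives 102 nM; the step of a 5.4-fold higher number from compound 2 to compound 3 (0.73 log units; beyond the scatter) is beyond the scatter.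

Compound 4 `COc1ccc(Cn2c(CCc3c[nH]c4ccccc34)nnc2[C@H](NC(=O)c2cnccn2)c2c[nH]c3ccccc23)c(OC)c1` is not yet measured. Its difference from compound 2 is pyrazin-2-yl in place of pyridin-2-yl on a carbonyl carbon. For the measured compounds named here, the only measured step that touches the carbonyl substituent is the one from compound 1 to compound 2, which was within the scatter despite exchanging 1-amino-1-methylethyl for pyridin-2-yl; the step from compound 2 to compound 3 concerns the methoxy group and does not bear on this change. Going by the values given here, no step adds a second ring nitrogen to the aryl carbonyl. The change is therefore expected to give no step beyond the scatter, a 1.3-fold higher number from compound 2 to compound 4 (0.12 log units; within the scatter). For compound 4 the expected value in this assay is 25 nM, with a range from 8 nM to 80 nM.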

Compound 4, antagonist equilibrium constant: 97 nM
For compound 4 the middle estimate is 3.9-fold (0.59 log units) below the measured one, and the stated range ends below it.
By their numbers in this assay, from the lowest: compounds 1 and 2 (each within the scatter of the next); then compounds 4 and 3 (each within the scatter of the next).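

In this assay, the carbonyl substituent proves sensitive to a change that leaves ring size and heavy-atom count unchanged: exchanging one ring carbon for nitrogen, pyrazin-2-yl in place of pyridin-2-yl, gives a step beyond the scatter (a 5.1-fold higher number from compound 2 to compound 4 (0.71 log units; beyond the scatter)). Pyrazin-2-yl also departs from the 1-amino-1-methylethyl group (a 6.9-fold higher number from compound 1 to compound 4 (0.84 log units; beyond the scatter)), whereas pyridin-2-yl stayed within the scatter of that group, so the position accepts two very different groups yet does not accept every aromatic ring. Nothing in hand bears on the cause of this step.

On these data alone, how phenyl, with no ring nitrogen, or pyrimidin-2-yl would read at this carbonyl carbon remains open. Also open, as far as these compounds go, is whether the pyrazin-2-yl step and the step for hydrogen in place of methoxy would add up in one compound.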